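A Methyl Group Added to Compound 2

A few compounds are considered here, and "the series" means these few. Any claim that something is new, unique, unknown or untested is made for them only; others in the source may bear on it.

In an ADME assay on HeLa cells (Homo sapiens) for cytotoxicity, read by MTT assay, with a stated time of 2 days (a lower number here means that less compound is tolerated, a higher number that more compound is tolerated), compound 1 `CNC(=O)c1cc(Oc2ccc3c(C)c(C(=O)OC)sc3c2)ccn1` gives 15700 nM and compound 2 `CCOC(=O)c1cc2ccc(Oc3ccccc3)cc2s1` gives 90100 nM, the higher of the two numbers, with a gap beyond the usual scatter. Compound 3 `CCOC(=O)c1sc2cc(Oc3ccccc3)ccc2c1C` differs from compound 2 in one place: methyl in place of hydrogen on an aromatic carbon. Compound 1, at 15700 nM, also bears a methyl in that place but differs elsewhere as well, so only a modest downward move is expected. The expected change is a 2.1-fold lower number from compound 2 to compound 3 (0.33 log units; beyond the scatter), towards a lower number. For compound 3 the estimated value is 42000 nM, within a range of 18000 nM to 90000 nM.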

Compound 3, half-maximal cytotoxic concentration: 47600 nM
Estimate against measurement, compound 3: 1.1-fold (0.05 log units) below; low and high end bracket the measured number.
By their numbers in this assay, from the lowest: compound 1; then compounds 3 and 2 (each within the scatter of the next).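

In this assay, methyl in place of hydrogen on this aromatic carbon, next to the ring atom that bears the ethoxycarbonyl group, gives a 1.9-fold lower number from compound 2 to compound 3 (0.28 log units; within the scatter) and so leaves no change that can be told from the scatter. Going by these compounds alone, compound 1 differs elsewhere as well, so only this pair isolates the position, and it shows that the methyl is tolerated here. Nothing available speaks to a cause for this result. The compounds shown leave open whether a larger group at this position, such as an ethyl chain, or an amine would also stay within the scatter of compound 2.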